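A few compounds are considered here, and "the series" means these few. Any claim that something is new, unique, unknown or untested is made for them only; others in the source may bear on it.

Working notes on the series.

Compound 2, structure `Cc1ccc(S(=O)(=O)NC(=O)Nc2ccccc2C(=O)/C=C/c2cc(O)ccc2[N+](=O)[O-])cc1`, gives 18.3 ug/mL in an ADME assay on the whole organism for cytotoxicity, with Artemia salina as the target, with a stated time of 24 h; on this read-out higher numbers stand for an effect only at larger amounts of compound and lower numbers for an effect already at smaller amounts. Among the compounds with values here, it stands as the higher of the two numbers in hand, but its only neighbour, compound 1 with structure `COc1ccc(/C=C/C(=O)c2ccccc2NC(=O)NS(=O)(=O)c2ccc(C)cc2)c(OC)c1`, gives 16 ug/mL in this assay, and the step of a 1.1-fold higher number from compound 1 to compound 2 (0.06 log units; within the scatter) lies within the scatter, so no order between compound 2 and compound 1 can be read from these two values.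

Compound 3, structure `Cc1ccc(S(=O)(=O)NC(=O)Nc2ccccc2C(=O)/C=C/c2cccc(F)c2)cc1`, is not yet measured in this assay. Its difference from compound 2 is 3-fluorophenyl in place of 5-hydroxy-2-nitrophenyl on a double-bonded chain carbon bound to a double-bonded chain carbon.

Within the data shown here, the one measured step, a 1.1-fold higher number from compound 1 to compound 2 (0.06 log units; within the scatter), is the only one that bears on this change: it likewise exchanged the whole aromatic group at the same place on the chain and left the number essentially unchanged. On that basis no step beyond the scatter is expected in this assay for compound 3, in either direction. The estimate for compound 3 in this assay is 17 ug/mL, with a range from 8 ug/mL to 36 ug/mL, which means an expected step of a 1.1-fold lower number from compound 2 to compound 3 (0.03 log units; within the scatter).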

Compound 3, concentration for half-maximal effect: 4.13 ug/mL
Compound 3: the middle estimate sits 4.1-fold (0.61 log units) above what was measured; measured number outside the range, below it.
By their numbers in this assay, from the lowest: compound 3; then compounds 1 and 2 (each within the scatter of the next).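

In this assay, the aromatic group on a double-bonded chain carbon bound to a double-bonded chain carbon proves able to shift the number: 3-fluorophenyl gives a 4.4-fold lower number from compound 2 to compound 3 (0.65 log units; beyond the scatter) and, against 2,4-dimethoxyphenyl, a 3.9-fold lower number from compound 1 to compound 3 (0.59 log units; beyond the scatter). The earlier exchange between two differently substituted groups gave no such separation, so this position is not indifferent to the group it carries, and compound 3 now has the lowest number of the series, with steps beyond the scatter to both other compounds. No measurement at hand accounts for the difference.

The compounds shown do not separate a contribution of the fluorine from that of losing the hydroxy, nitro or methoxy groups, and an unsubstituted phenyl or a 3-chlorophenyl at this place would bear directly on that question. Going by these compounds, it also remains open whether the number depends on where the fluorine sits on the ring, and whether a phenyl group carrying an amine or a carboxylic acid would stay near compound 3 or near compounds 1 and 2.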